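Replacing the pyrrolidine tail of compound 3

A few compounds are considered here, and "the series" means these few. Any claim that something is new, unique, unknown or untested is made for them only; others in the source may bear on it.

Three compounds were measured in a functional assay on HT-29 cells (Homo sapiens) for antiproliferative activity, read by MTT assay, with a stated time of 72 h; on this read-out higher numbers stand for weaker inhibition and lower numbers for stronger inhibition:

compound 1, `COc1cc2c(Oc3ccc(NC(=O)NN4C(=O)CSC4c4c(F)cccc4F)c4ccccc34)ccnc2cc1OCCCN1CCCC1`, gives 1860 nM
compound 2, `COc1cc2c(Oc3c(F)cc(NC(=O)NN4C(=O)CSC4c4c(F)cccc4F)cc3F)ccnc2cc1OCCCN1CCCC1`, gives 230 nM
compound 3, `COc1cc2c(Oc3c(F)cc(NC(=O)NN4C(=O)CCSC4c4c(F)cccc4F)cc3F)ccnc2cc1OCCCN1CCCC1`, gives 270 nM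

On these three numbers compound 3 stands second highest. Its nearest neighbour is compound 2, whose number lies within the scatter of repeated measurements, so the two cannot be told apart in this assay. The furthest is compound 1, whose number is higher, and that gap lies beyond the scatter; compound 1 and compound 3 also differ in more than one place, so their two values only show that compound 1 is the weaker inhibitor of the three.

Compound 4, `COc1cc2c(Oc3c(F)cc(NC(=O)NN4C(=O)CCSC4c4c(F)cccc4F)cc3F)ccnc2cc1OCCCN1CCc2sccc2C1`, is not yet measured. It differs from compound 3 in one place: a group of 9 heavy atoms (7 carbon, 1 nitrogen, 1 sulfur; one five-membered aromatic ring with 1 hetero atom, one six-membered non-aromatic ring with 1 hetero atom) in place of a group of 5 heavy atoms (4 carbon, 1 nitrogen; one five-membered non-aromatic ring with 1 hetero atom), on a saturated chain carbon, three bonds along the chain from an oxygen on an aromatic ring. Among the measured compounds shown here, no pair of measured compounds shows the effect of a change at this point of the chain, so there is nothing in the data to set a direction. The step from compound 3 to compound 4 is therefore expected to be small, a 1.1-fold higher number from compound 3 to compound 4 (0.05 log units; within the scatter), not beyond the scatter in either direction. Compound 4 is accordingly estimated at 300 nM in this assay, with a range from 100 nM to 900 nM.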

Compound 4, half-maximal inhibitory concentration: 1320 nM
Compound 4: middle estimate off by 4.4-fold (0.64 log units), on the low side; the measured number lies above the stated range.
By their numbers in this assay, from the lowest: compounds 2 and 3 (each within the scatter of the next); then compounds 4 and 1 (each within the scatter of the next).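

Among the compounds shown here, this is the first measured change at this point of the chain. In this assay, the group of 9 heavy atoms in place of pyrrolidin-1-yl gives a 4.9-fold higher number from compound 3 to compound 4 (0.69 log units; beyond the scatter), which shows that the number responds to what sits on this saturated chain carbon, three bonds along the chain from an oxygen on an aromatic ring, whereas compound 1, compound 2 and compound 3 all carry pyrrolidin-1-yl there and could not show this. Nothing measured here accounts for the step, so it stands as an observation about this one replacement.

The compounds shown leave open which feature of the entering group goes with the weaker inhibition, since its additional ring, its sulfur and its greater number of heavy atoms all arrive in a single change, and a piperidine, a morpholine or a dimethylamino group on the same chain would help to separate them. They also leave open whether a longer chain carrying the same group, or the same replacement on compound 2, would give a step of similar size.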